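Pyridin-4-yl for pyridin-3-yl: what to expect of compound 4

A few compounds are considered here, and "the series" means these few. Any claim that something is new, unique, unknown or untested is made for them only; others in the source may bear on it.

Four compounds are compared; two pairs differ only in how a pyridine ring is attached. Compound 1 (`O=C(/C=C/c1cn(-c2ccccc2)nc1-c1cccnc1)c1ccsc1`) carries a pyridin-3-yl group, and in a functional assay on HCT-116 cells (Homo sapiens) for inhibition, read by sulforhodamine B assay, with a stated time of 72 h (on this read-out lower numbers stand for stronger inhibition and higher numbers for weaker inhibition), compound 1 gives a reading of 1300 nM at this concentration scale. Compound 3 (`O=C(/C=C/c1cn(-c2ccccc2)nc1-c1ccncc1)c1ccsc1`) differs from it by pyridin-4-yl in place of pyridin-3-yl on an aromatic carbon and shows a 1.2-fold lower number from compound 1 to compound 3 (0.07 log units; within the scatter) in this assay, so the two readings cannot be told apart. Compound 2 (`COc1cc(OC)c(C(=O)/C=C/c2cn(-c3ccccc3)nc2-c2cccnc2)c(OC)c1`) has a different core; how its core differs from that of compound 1 is not broken down here. In this assay compound 2 gives the lowest reading with 300 nM and its nearest neighbour is compound 3 with 1100 nM as reading. Compound 4 (`COc1cc(OC)c(C(=O)/C=C/c2cn(-c3ccccc3)nc2-c2ccncc2)c(OC)c1`) is unmeasured and stands to compound 2 as compound 3 stands to compound 1, through (pyridin-4-yl in place of pyridin-3-yl on an aromatic carbon); the surroundings read slightly differently, since the neighbouring ring atom bears a large group rather than a group of 9 heavy atoms, so this is the same kind of change rather than the same. The step of a 1.2-fold lower number from compound 2 to compound 4 (0.08 log units; within the scatter) is expected to be similarly small, because the earlier version of this change gave a 1.2-fold lower number from compound 1 to compound 3 (0.07 log units; within the scatter) in this assay. Compound 4 is therefore estimated at 250 nM in this assay, with a plausible range from 120 nM to 600 nM in the same assay.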

Compound 4, half-maximal inhibitory concentration: 600 nM
Beside the measured number, compound 4's estimate is 2.4-fold (0.38 log units) below it, within the range that was stated.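

In this assay, putting pyridin-4-yl in place of pyridin-3-yl gives a 2.0-fold higher number from compound 2 to compound 4 (0.30 log units; within the scatter), so this step, like the earlier one, is too small to separate from the differences seen between repeated measurements. Set side by side, the two steps do not differ by more than that scatter allows: the same change on two cores in this assay, a 1.2-fold lower number (0.07 log units; within the scatter) from compound 1 to compound 3 and a 2.0-fold higher number (0.30 log units; within the scatter) from compound 2 to compound 4, 2.4-fold (0.37 log units) apart, within the scatter of two such steps. Within the data shown here, on these two cores, then, the swap can be carried from one to the other without a readable effect on the number, but this rests on only two pairs of compounds: it does not show that the swap would be as quiet on any other core, and a small real difference could still hide inside the scatter.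

The compounds shown leave open whether pyridin-2-yl, or a plain phenyl ring in the same place, would read like these two pyridines. Also open, as far as these compounds go, is whether the swap stays this small on a core carrying an amine or a carboxylic acid.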